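A few compounds are considered here, and "the series" means these few. Any claim that something is new, unique, unknown or untested is made for them only; others in the source may bear on it.

Compounds measured in a functional assay on PC-3 cells (Homo sapiens) for antiproliferative activity, read by MTT assay, with a stated time of 48 h; a higher number here means a weaker inhibitor, a lower number a stronger inhibitor:
Compound 1 `O=C1c2ccccc2C(=O)N1c1nc(-c2ccccc2)cs1` gives 43900 nM.
Compound 2 `O=C1c2ccccc2C(=O)N1c1nc(-c2ccc(Cl)cc2)cs1` gives 44900 nM.
Compound 3 `N#Cc1ccc(-c2csc(N3C(=O)c4ccccc4C3=O)n2)cc1` gives 40300 nM.

Compound 3 sits alongside compounds 1 and 2 on these numbers, since a 1.1-fold lower number from compound 1 to compound 3 (0.04 log units; within the scatter) and a 1.1-fold lower number from compound 2 to compound 3 (0.05 log units; within the scatter) both fall within the scatter, as does a 1.0-fold higher number from compound 1 to compound 2 (0.01 log units; within the scatter). Compound 4 `O=C1c2ccccc2C(=O)N1c1nc(-c2ccc([N+](=O)[O-])cc2)cs1` differs from compound 3 by nitro in place of cyano on an aromatic carbon. Within the data shown here, the steps that bear on this change are the ones at the same position: a 1.1-fold lower number from compound 1 to compound 3 (0.04 log units; within the scatter) and a 1.1-fold lower number from compound 2 to compound 3 (0.05 log units; within the scatter). Neither moved the number beyond the scatter, so no step beyond the scatter is expected in this assay for compound 4 either. Compound 4 is therefore estimated at 41000 nM, with a range of 20000 nM to 85000 nM, which means an expected step of a 1.0-fold higher number from compound 3 to compound 4 (0.01 log units; within the scatter).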

Compound 4, half-maximal inhibitory concentration: 41800 nM
Compound 4: the middle estimate sits 1.0-fold (0.01 log units) below what was measured; measured number inside the range.
By their numbers in this assay, from the lowest: compounds 3, 4, 1 and 2 (each within the scatter of the next).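

At this position, on an aromatic carbon para to a large group, nitro also stays within the scatter in this assay, as the three new steps show: a 1.0-fold higher number from compound 3 to compound 4 (0.02 log units; within the scatter) and a 1.1-fold lower number from compound 2 to compound 4 (0.03 log units; within the scatter) and a 1.1-fold lower number from compound 1 to compound 4 (0.02 log units; within the scatter) and each of these is within the scatter. Hydrogen, chloro, cyano and nitro at this one place therefore all give numbers within the scatter of one another. Whether an amine, a carboxylic acid or a longer chain here would move the number stays open, and nothing available explains why these four groups give such similar numbers.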